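Swapping the Pyrrole on Compound 3 for a Pyrazole

This account rests on a few compounds, and the source may have more. Where it says the series, first, only, none or still open, it means among the compounds named here.

Compound 1 `COc1ccc2[nH]c(-c3ccc[nH]3)c(C3CC(=O)NC3=O)c2c1` - 600 nM
Compound 2 `c1ccc2[nH]c(-n3cccn3)cc2c1` - > 100000 nM (a limit of the assay, not a number)
Compound 3 `COc1ccc2[nH]c(-c3ccc[nH]3)cc2c1` - 61000 nM

All three were tested in a functional assay on B16-F10 cells (Mus musculus) for cytotoxicity, read by MTT assay, with a stated time of 72 h; a higher number here means a weaker inhibitor, a lower number a stronger inhibitor. Only compound 1 and compound 3 have true numbers, and compound 3 has the higher of the two, so it is the weaker inhibitor. The measured step between them is a 100-fold higher number from compound 1 to compound 3 (2.01 log units; beyond the scatter).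

The next compound, compound 4 `COc1ccc2[nH]c(-n3cccn3)cc2c1`, keeps the core of compound 3 but changes one group, on an aromatic carbon next to the ring nitrogen: 1H-pyrazol-1-yl in place of 1H-pyrrol-2-yl on an aromatic carbon.

For the measured compounds named here, the one measured step concerns the loss of a 2,5-dioxopyrrolidin-3-yl group, so despite its large size it says nothing direct about this swap. The closest clue is compound 2, which also carries 1H-pyrazol-1-yl but lacks the methoxy group of compound 4. The value of compound 2, > 100000 nM, is a limit of the assay.

On this thin evidence, no step beyond the scatter is expected in this assay, though any drift should lean toward a higher number. The expected change is a 1.3-fold higher number from compound 3 to compound 4 (0.12 log units; within the scatter). For compound 4 the estimated value is 80000 nM, with an expected range of 30000 nM to 150000 nM.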

Compound 4, half-maximal inhibitory concentration: > 100000 nM
Compound 4: only a limit was reported (the forecaster's own chance of this, stated with the estimate: 40%); middle value at least 1.2-fold (0.09 log units) from the limit.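

Compound 4 is reported only as a limit of the assay, > 100000 nM, and not as a true number. For the compounds shown here, at this place, on an aromatic carbon next to the ring nitrogen, putting 1H-pyrazol-1-yl in place of 1H-pyrrol-2-yl gives the first direct reading of this swap in this assay, an at least 1.6-fold higher number from compound 3 to compound 4 (0.21 log units; that floor lies within the scatter), so the step could be larger, but the floor alone does not show a change beyond the scatter. The step from compound 2 to compound 4, which adds methoxy, cannot be read, because both compounds stop at the same limit: the limit of > 100000 nM in this assay, at which 2 of the 4 values shown sit.

The compounds shown leave open whether the swap would matter with the 2,5-dioxopyrrolidin-3-yl group of compound 1 present, since that group gave the only clearly large step so far and the pair that would test this is absent here. They also leave open how other groups at this place, such as an amine, a carboxylic acid or a phenyl ring, would compare with the 1H-pyrrol-2-yl group, which carries a hydrogen-bond donor that 1H-pyrazol-1-yl lacks.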